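Swapping the amide aryl group of a P2X7 antagonist

The compounds below may be only part of what the source reports. "The series", "measured", "known", "first", "only" and "open" are said of these compounds alone.

Among the compounds with values here, compound 3 `O=C(c1ccc(Cl)c(C(F)(F)F)c1)N1CCC(n2cncc2-c2ccc(OS(=O)(=O)c3cccc4cnccc34)cc2)CC1` gives 45 nM in an assay on HEK293 cells for antagonist activity at P2X purinoceptor 7 (Homo sapiens), read by fluorescence, with a stated time of 2 h (a higher number here means a weaker inhibitor, a lower number a stronger inhibitor), the lowest of the three numbers known so far, though its steps from compound 1 `N#Cc1cccc(S(=O)(=O)Oc2ccc(-c3cncn3C3CCN(C(=O)c4ccc(Cl)c(C(F)(F)F)c4)CC3)cc2)c1` at 73 nM and from compound 2 `O=C(NC1CC1)c1cccc(S(=O)(=O)Oc2ccc(-c3cncn3C3CCN(C(=O)c4ccc(Cl)c(C(F)(F)F)c4)CC3)cc2)c1` at 88 nM were a 1.6-fold lower number from compound 1 to compound 3 (0.21 log units; within the scatter) and a 2.0-fold lower number from compound 2 to compound 3 (0.29 log units; within the scatter), both within the scatter. Compound 4 `CC(C)(O)c1ccc(C(=O)N2CCC(n3cncc3-c3ccc(OS(=O)(=O)c4cccc5cnccc45)cc3)CC2)cc1` differs from compound 3 by 4-(1-hydroxy-1-methylethyl)phenyl in place of 4-chloro-3-(trifluoromethyl)phenyl on a carbonyl carbon. Every measured step, including a 1.2-fold higher number from compound 1 to compound 2 (0.08 log units; within the scatter), altered the group on the sulfonyl sulfur, so none bears on a change at the carbonyl carbon; the known compounds give no guide to its size or direction. The expectation for compound 4 is therefore a step of a 2.0-fold higher number from compound 3 to compound 4 (0.30 log units; within the scatter), centred close to compound 3 with a wide range. Compound 4 is estimated at 90 nM, between 25 nM and 400 nM.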

Compound 4, half-maximal inhibitory concentration: 109 nM
Estimate against measurement, compound 4: 1.2-fold (0.08 log units) below; the measured number falls inside the stated range.
By their numbers in this assay, from the lowest: compounds 3, 1, 2 and 4 (each within the scatter of the next, the first and the last beyond it).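

This is the first change shown on the carbonyl carbon: 4-(1-hydroxy-1-methylethyl)phenyl in place of 4-chloro-3-(trifluoromethyl)phenyl gives a 2.4-fold higher number from compound 3 to compound 4 (0.38 log units; beyond the scatter), whereas each step on the sulfonyl sulfur stayed within the scatter. The aryl group here can therefore lose its chlorine and trifluoromethyl and gain a hydrogen-bond donor at only a modest cost. No measurement is available to explain this shift.

On these data alone, the swap changes several features at once, so the contribution of each remains open. Also open, as far as these compounds go, is how a phenyl group bearing an amine or a carboxylic acid would compare with compound 3.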